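Swapping a heptyl for 4-bromophenyl on a triazole series

The source may hold more compounds than are shown below. What is called first, only, known or untested is meant among the compounds shown, and "the series" means these compounds.

Compound 1, `CCCCCCCCn1cc(/C=C/C(=O)c2ccc(N)cc2)nn1`, is the smallest of the set, and in a functional assay on MCF7 cells (Homo sapiens) for inhibition, read by MTT assay (a higher number here means a weaker inhibitor, a lower number a stronger inhibitor), compound 1 gives 31000 nM. Compound 2, `CCCCCCCCn1cc(/C=C/C(=O)c2ccc(NC(=O)CN3CCN(c4ccc([N+](=O)[O-])cc4)CC3)cc2)nn1`, carries a longer chain on the aromatic amine; in this assay compound 2 gives 49100 nM. Compound 3, `O=C(CN1CCN(c2ccc([N+](=O)[O-])cc2)CC1)Nc1ccc(C(=O)/C=C/c2cn(Cc3ccc(Br)cc3)nn2)cc1`, differs from compound 2 in one place, (4-bromophenyl in place of heptyl on a saturated chain carbon bound to an aromatic nitrogen), and in this assay compound 3 gives 31600 nM. That single change moved the number a 1.6-fold lower number from compound 2 to compound 3 (0.19 log units; within the scatter). The difference between the core of compound 1 and the core of compound 2 is not broken down here.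

Compound 4, `Nc1ccc(C(=O)/C=C/c2cn(Cc3ccc(Br)cc3)nn2)cc1`, has not yet been measured in this assay. It differs from compound 1 by 4-bromophenyl in place of heptyl on a saturated chain carbon bound to an aromatic nitrogen, the same change that separates compound 2 from compound 3. Since the measured pair moved only a 1.6-fold lower number from compound 2 to compound 3 (0.19 log units; within the scatter), compound 4 is expected to show a step of a 1.3-fold lower number from compound 1 to compound 4 (0.11 log units; within the scatter). On that basis compound 4 is estimated to give about 24000 nM in this assay, with a plausible range from 9000 nM to 65000 nM.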

Compound 4, half-maximal inhibitory concentration: 25300 nM
For compound 4 the middle estimate is 1.1-fold (0.02 log units) below the measured one; the range from low to high includes it.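

In this assay, putting 4-bromophenyl in place of heptyl on the core of compound 1 gives a 1.2-fold lower number from compound 1 to compound 4 (0.09 log units; within the scatter). Set beside the earlier step, the change reads the same on both cores: the same change on two cores in this assay, a 1.6-fold lower number (0.19 log units; within the scatter) from compound 2 to compound 3 and a 1.2-fold lower number (0.09 log units; within the scatter) from compound 1 to compound 4, 1.3-fold (0.10 log units) apart, within the scatter of two such steps. This shows that the change carries from one core to the other without a detectable difference, but both steps lie within the scatter, so neither shows that the change moves the number at all, and two cores cannot establish how it would behave on a third.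

The compounds shown leave open whether any other group on a saturated chain carbon bound to an aromatic nitrogen, such as a longer chain, an amine or a carboxylic acid, would give a step beyond the scatter. They also leave open whether the change would still read the same on a core that carries a different group on the aromatic amine, such as a simple acetyl amide.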